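The source may report more compounds than this note shows. Statements on the series, on what has been measured and on what is new or still open speak of the compounds shown alone.

Among the two compounds measured in a functional assay on WM 266-4 cells (Homo sapiens) for antiproliferative activity, read by MTT assay, with a stated time of 24 h (a higher number here means a weaker inhibitor of growth, a lower number a stronger inhibitor of growth), compound 1 `c1ccc(COc2ccc(C3CC(c4ccc5c(c4)OCCO5)=NN3c3ccccc3)cc2)cc1` stands at the lower end: it gives 1130 nM. The other measured compound, compound 2 `Fc1ccccc1C1CC(c2ccc3c(c2)OCCO3)=NN1c1ccccc1`, carries a different aryl group on the shared core and gives 9120 nM, a number well beyond the scatter above that of compound 1, so compound 1 is the stronger growth inhibitor of the pair.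

Compound 3 `CSc1ccc(C2CC(c3ccc4c(c3)OCCO4)=NN2c2ccccc2)cc1` has not yet been measured in this assay. It differs from compound 1 in one place: methylsulfanyl in place of benzyloxy on an aromatic carbon. Within the data shown here, no measured pair in this set shows the same change, so the expected size of the step can only be judged from the two numbers known. Because compound 2 gives 9120 nM with a much smaller aryl substituent than the benzyloxy-bearing compound 1, a move toward a smaller group is expected to weaken rather than strengthen growth inhibition, by a moderate step beyond the scatter, as the estimated 2.7-fold higher number from compound 1 to compound 3 (0.42 log units; beyond the scatter) expresses. Compound 3 is therefore estimated at 3000 nM, with a likely range from 1000 nM to 9000 nM.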

Compound 3, concentration for 50% growth inhibition: 6870 nM
Beside the measured number, compound 3's estimate is 2.3-fold (0.36 log units) below it; the measured number falls inside the stated range.
By their numbers in this assay, from the lowest: compound 1; then compounds 3 and 2 (each within the scatter of the next).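

In this assay, among these compounds, methylsulfanyl in place of benzyloxy on the aromatic carbon, para to a large group, gives a 6.1-fold higher number from compound 1 to compound 3 (0.78 log units; beyond the scatter), the first direct reading of a change at this position. The change takes away a six-membered aromatic ring of carbon only and reduces the group from 8 heavy atoms to 2, while each group carries 1 hydrogen-bond acceptor. 4-(Methylsulfanyl)phenyl in place of 2-fluorophenyl on a saturated ring carbon gives a 1.3-fold lower number from compound 2 to compound 3 (0.12 log units; within the scatter), so compound 1 alone stands apart from the other two, and its benzyloxy group is the one feature here tied to a lower number. Nothing measured alongside these numbers accounts for the step.

The compounds shown leave open whether the loss follows the removal of the benzyl part or the exchange of the oxygen-linked group for a sulfur-linked one. A methoxy group and a benzylsulfanyl group at the same place would separate these two changes, and a longer chain such as phenethyloxy would show whether growth inhibition improves further beyond benzyloxy.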